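From fluoro to chloro on the shared core

A few compounds are considered here, and "the series" means these few. Any claim that something is new, unique, unknown or untested is made for them only; others in the source may bear on it.

Compound 1 `O=C(/C=C/c1cccc(S(=O)(=O)c2ccc3ccccc3n2)c1)NO`: 80 nM
Compound 2 `O=C(/C=C/c1cccc(S(=O)(=O)c2ccc3cccc(F)c3n2)c1)NO`: 440 nM

In a functional assay on HCT-116 cells (Homo sapiens) for antiproliferative activity, read by sulforhodamine B assay, with a stated time of 48 h (a lower number here means a stronger inhibitor of growth, a higher number a weaker inhibitor of growth), compound 2 holds the higher of the two numbers, at 440 nM. The next structure, compound 3 `O=C(/C=C/c1cccc(S(=O)(=O)c2ccc3cccc(Cl)c3n2)c1)NO`, differs from it as follows: chloro in place of fluoro on an aromatic carbon. In words, this is chloro in place of fluoro on an aromatic carbon. Within the data shown here, no measured step swaps one halogen for another. Among the measured compounds shown here, the only guide is a 5.5-fold higher number from compound 1 to compound 2 (0.74 log units; beyond the scatter), which came from fluoro in place of hydrogen on an aromatic carbon and lies beyond the scatter. In this assay, a smaller change than that is expected here, perhaps slightly upward and probably not beyond the scatter. The expected size is a 1.1-fold higher number from compound 2 to compound 3 (0.06 log units; within the scatter). The estimate for compound 3 is 500 nM, with an expected range of 200 nM to 1200 nM.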

Compound 3, concentration for 50% growth inhibition: 1310 nM
For compound 3 the middle estimate is 2.6-fold (0.42 log units) below the measured one, and the stated range ends below it.
By their numbers in this assay, from the lowest: compound 1; then compound 2; then compound 3.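

In this assay, this position responds not only to whether a halogen is present but also to which one: chloro in place of fluoro gives a 3.0-fold higher number from compound 2 to compound 3 (0.47 log units; beyond the scatter) and so separates the two halogens, which the earlier pair could not do. Chloro in place of hydrogen gives a 16-fold higher number from compound 1 to compound 3 (1.21 log units; beyond the scatter) and places the three compounds in the order hydrogen, fluoro, chloro from the lowest number to the highest, with none of them going against that order. No measurement shown here accounts for this order.

The compounds shown leave open whether bromo, methyl, methoxy or an amine on this same aromatic carbon would continue that order or break it. They also leave open whether fluoro or chloro on another carbon of the shared core would give steps of a similar size.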